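A few compounds are considered here, and "the series" means these few. Any claim that something is new, unique, unknown or untested is made for them only; others in the source may bear on it.

Compound 1 `COc1ccc(Nc2nc3ccccc3nc2S(=O)(=O)c2ccc(OC)cc2)cc1` gives 29100 nM in a functional assay on HCT-116 cells (Homo sapiens) for cytotoxicity, read by MTT assay, with a stated time of 72 h; on this read-out higher numbers stand for weaker inhibition and lower numbers for stronger inhibition. Compound 2 `COc1ccc(S(=O)(=O)c2nc3ccccc3nc2Nc2cc(OC)cc(OC)c2)cc1` differs from it by 3,5-dimethoxyphenyl in place of 4-methoxyphenyl on a nitrogen on an aromatic ring, and that change produced a 2.2-fold lower number from compound 1 to compound 2 (0.34 log units; beyond the scatter). Compound 3 `COc1ccc(Nc2nc3ccccc3nc2S(=O)(=O)c2ccc(F)cc2)cc1` differs from compound 1 by fluoro in place of methoxy on an aromatic carbon, and in this assay compound 3 gives 3010 nM, while compound 2 gives 13400 nM; the step it made was a 9.7-fold lower number from compound 1 to compound 3 (0.99 log units; beyond the scatter). Compound 4 `COc1cc(Nc2nc3ccccc3nc2S(=O)(=O)c2ccc(F)cc2)cc(OC)c1` has not been measured; it differs from compound 3 by 3,5-dimethoxyphenyl in place of 4-methoxyphenyl on a nitrogen on an aromatic ring, the same change that took compound 1 to compound 2. Applying that earlier step to compound 3, the step from compound 3 to compound 4 is expected to be about a 2.0-fold lower number from compound 3 to compound 4 (0.30 log units; within the scatter), because the one shown instance gave a 2.2-fold lower number from compound 1 to compound 2 (0.34 log units; beyond the scatter) and a single example supports only a loose transfer. Compound 4 is therefore estimated at 1500 nM, within a range from 600 nM to 4000 nM.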

Compound 4, half-maximal inhibitory concentration: 3930 nM
Compound 4: the middle estimate sits 2.6-fold (0.42 log units) below what was measured, within the range that was stated.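

In this assay, 3,5-dimethoxyphenyl in place of 4-methoxyphenyl on the nitrogen did not carry over unchanged from one core to the other, giving a 1.3-fold higher number from compound 3 to compound 4 (0.12 log units; within the scatter): the same change on two cores in this assay, a 2.2-fold lower number (0.34 log units; beyond the scatter) from compound 1 to compound 2 and a 1.3-fold higher number (0.12 log units; within the scatter) from compound 3 to compound 4, 2.8-fold (0.45 log units) apart, beyond the scatter of two such steps. Fluoro in place of methoxy kept its direction on both cores but not its size, giving a 3.4-fold lower number from compound 2 to compound 4 (0.53 log units; beyond the scatter): the same change on two cores in this assay, a 9.7-fold lower number (0.99 log units; beyond the scatter) from compound 1 to compound 3 and a 3.4-fold lower number (0.53 log units; beyond the scatter) from compound 2 to compound 4, 2.8-fold (0.45 log units) apart, beyond the scatter of two such steps. Among the compounds shown here, with only two cores for each change, neither step transfers here as a fixed amount, but the data do not show what sets the size of either step.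

The compounds shown leave open how these steps would run with chloro or trifluoromethyl in place of the fluoro, or with an amine or a carboxylic acid on the aromatic ring carried by the nitrogen. They also leave open whether the same steps would hold on other cells.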